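The source may hold more compounds than are shown below. What is called first, only, known or untested is meant among the compounds shown, and "the series" means these compounds.

In an assay on isolated protein for displacement of a labelled ligand from metabotropic glutamate receptor 5 (Homo sapiens), with a stated time of 60 min, tested at 1 uM (on this read-out higher numbers stand for more inhibition at the one concentration tested (going by the name of the read-out) and lower numbers for less inhibition), compound 3 `CC1CCN(c2c(S(=O)(=O)c3ccc(F)c(F)c3)cnc3cc(Cl)ccc23)CC1` gives 90%, the largest of the three numbers in hand. The nearest is compound 1 `Cc1ccc(S(=O)(=O)c2cnc3cc(Cl)ccc3c2N2CCC(C)CC2)cc1F`, which gives 85%; the gap is described by a number 5 percentage points higher from compound 1 to compound 3 (within the scatter), so the two cannot be ordered. Compound 2 `CC1CCN(c2c(S(=O)(=O)c3ccc(C#N)cc3)cnc3cc(Cl)ccc23)CC1` gives 70%, and here the difference is a number 20 percentage points higher from compound 2 to compound 3 (beyond the scatter).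

Compound 4 `CC1CCN(c2c(S(=O)(=O)c3cc(F)cc(F)c3)cnc3cc(Cl)ccc23)CC1` is built from the same atoms as compound 3, joined differently: 3,5-difluorophenyl in place of 3,4-difluorophenyl on a sulfonyl sulfur.

Two kinds of measured step speak to this change. Exchanging one whole aryl group on the sulfonyl sulfur for another gave a number 15 percentage points lower from compound 1 to compound 2 (beyond the scatter) and a number 20 percentage points higher from compound 2 to compound 3 (beyond the scatter), both modest. Exchanging a single substituent on that ring, fluoro in place of methyl on an aromatic carbon, gave a number 5 percentage points higher from compound 1 to compound 3 (within the scatter), within the scatter. Within the data shown here, no measured pair shifts a fluorine from one position to another on an otherwise unchanged ring, so the move from compound 3 to compound 4 has no direct precedent; the closest analogy, the substituent swap, was silent. Compound 4 is therefore expected to show a step of a number 6 percentage points lower from compound 3 to compound 4 (within the scatter), that is, nothing beyond the scatter. The estimate for compound 4 in this assay is 84%, with a range from 68% to 96%.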

Compound 4, a percentage reported as inhibition, at one concentration (the size of the read-out at that concentration, not a potency): 94%
Compound 4: middle estimate off by 10 percentage points, on the low side, within the range that was stated.
By their numbers in this assay, from the lowest: compound 2; then compounds 1, 3 and 4 (each within the scatter of the next).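

In this assay, 3,5-difluorophenyl in place of 3,4-difluorophenyl on a sulfonyl sulfur gives a number 4 percentage points higher from compound 3 to compound 4 (within the scatter), the first measured case of the same atoms being rearranged on this ring, and the two arrangements cannot be told apart. The 3,5-difluorophenyl group also cannot be separated from 3-fluoro-4-methylphenyl, with a number 9 percentage points higher from compound 1 to compound 4 (within the scatter), whereas replacing 4-cyanophenyl with it gives a number 24 percentage points higher from compound 2 to compound 4 (beyond the scatter), so among the four aryl groups at this position only the 4-cyanophenyl compound stands apart from the others. No supporting evidence accounts for these steps or for the lack of separation among the three compounds with fluorinated aryl groups.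

The compounds shown leave open whether compound 1, compound 3 and compound 4 would show a stronger or weaker effect at any other concentration; only one concentration was tested. They also leave open how this position would respond to a ring carrying a methoxy group, a trifluoromethyl group or a carboxylic acid, or to a single fluorine in place of the two.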